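Swapping the Acid Arm for a Thioether Arm

The source may hold more compounds than are shown below. What is called first, only, known or untested is meant among the compounds shown, and "the series" means these compounds.

In a functional assay on the whole organism (Tail, strain ICR) with Mus musculus as the target, in the tail flick test, with a stated time of 120 min, at a dose of 25 umol/kg by the oral route (on this read-out higher numbers stand for a stronger effect at the one dose given and lower numbers for a weaker effect), three compounds sharing one core have been measured. Compound 1 `O=C(O)CC[C@H](NC(=O)CN(c1nc(Cl)nc2[nH]cnc12)C1CC1)C(=O)O` gives 30.1%. Compound 2 `CSCC[C@H](NC(=O)CN(c1nc(Cl)nc2[nH]cnc12)C1CC1)C(=O)OCc1ccccc1`, which carries a benzyl ester and a different side chain, gives 31.6%. Compound 3 `O=C(O)C[C@H](NC(=O)CN(c1nc(Cl)nc2[nH]cnc12)C1CC1)C(=O)O` gives 22%, the lowest of the three numbers, although its gaps to compound 1 and to compound 2 both fall within the scatter, so the three cannot be told apart.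

Compound 4 `CSCC[C@H](NC(=O)CN(c1nc(Cl)nc2[nH]cnc12)C1CC1)C(=O)O` has not yet been measured. It differs from compound 3 in one place: (methylsulfanyl)methyl in place of carboxy on a saturated chain carbon, two bonds along the chain from an amide-type nitrogen and a carbonyl carbon. Going by the values given here, the only measured step of this kind, a number 8.1 percentage points lower from compound 1 to compound 3 (within the scatter), changed the same chain carbon and stayed within the scatter. Among the compounds with values here, no measured step changes carboxy for (methylsulfanyl)methyl, so the bearing is indirect; compound 2 carries the same 1-carboxy-3-(methylsulfanyl)propyl arm as compound 4 but as a benzyl ester, and its number sits with the others. Given that every measured difference here has stayed within the scatter, the step to compound 4 is expected to stay within it too, a number 6 percentage points higher from compound 3 to compound 4 (within the scatter). The activity of compound 4 is therefore estimated at 28%, with a range from 15% to 42%.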

Compound 4, a percentage reported as activity, at one dose (the size of the read-out at that dose, not a potency): 5.67%
Beside the measured number, compound 4's estimate is 22.3 percentage points above it; the measured number lies below the stated range.
By their numbers in this assay, from the lowest: compound 4; then compounds 3, 1 and 2 (each within the scatter of the next).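

Going by these compounds alone, the position is not as tolerant as the earlier compounds suggested: the only step previously seen on this chain carbon, a number 8.1 percentage points lower from compound 1 to compound 3 (within the scatter), stayed within the scatter, whereas (methylsulfanyl)methyl in place of carboxy gives a number 16.3 percentage points lower from compound 3 to compound 4 (beyond the scatter). The same holds one bond further out, where methylsulfanyl in place of carboxy, three bonds along the chain from an amide-type nitrogen and a carbonyl carbon, gives a number 24.4 percentage points lower from compound 1 to compound 4 (beyond the scatter), so both acid arms stand apart from the thioether arm once the other end of the molecule carries a free acid. The thioether arm alone therefore does not set the number, since hydrogen in place of benzyl on an oxygen next to a carbonyl group gives a number 25.9 percentage points lower from compound 2 to compound 4 (beyond the scatter), and the benzyl ester of compound 2 is what separates it from compound 4.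

Nothing available here gives a reason for these losses. Going by these compounds, it remains open whether a smaller ester such as a methyl ester would restore the number of the thioether compound, and whether an amine or a longer chain at this same chain carbon would behave like the acid arms or like the thioether arm.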